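Replacing the (methoxycarbonyl)carbonyl group with hydrogen on the amine nitrogen

This account rests on a few compounds, and the source may have more. Where it says the series, first, only, none or still open, it means among the compounds named here.

Compound 1 `N#CC1=C(NCC(=O)O)N(c2ccccc2)C(=O)N2CCCCC(N3CCCC3)C12` gives 53.4% in a functional assay on the whole organism (strain albino) for inhibition, with Rattus norvegicus as the target, read by paw edema, with stated times of 1 h and 3 h, at a dose of 12 mmol/kg by the intraperitoneal route; a lower number here means a weaker effect, a higher number a stronger effect of the compound at the dose given.
Compound 2 `COC(=O)C(=O)NC1=C(C#N)C2C(N3CCCC3)CCCCN2C(=O)N1c1ccccc1` gives 49.3% in this assay.

On these two numbers compound 2 stands lowest, with compound 1 as its nearest neighbour, but the gap between them lies within the scatter, so the two compounds are taken as level in this assay. Compound 3 `N#CC1=C(N)N(c2ccccc2)C(=O)N2CCCCC(N3CCCC3)C12` differs from compound 2 by hydrogen in place of (methoxycarbonyl)carbonyl on an amine nitrogen. Among the compounds with values here, the one measured step that touches the same amine nitrogen, a number 4.1 percentage points lower from compound 1 to compound 2 (within the scatter), exchanged one substituent for another and moved the read-out by an amount inside the scatter. Within the data shown here, no measured step removes the substituent from that nitrogen entirely, so the effect of leaving only hydrogen there is not covered by the data. With nothing pointing either way, compound 3 is expected to stay close to compound 2, and the step of a number 1.3 percentage points lower from compound 2 to compound 3 (within the scatter) is expected not to exceed the scatter in either direction. Compound 3 is therefore estimated at 48% in this assay, with a range from 30% to 65%.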

Compound 3, a percentage reported as inhibition, in the whole organism at one dose (the size of the read-out at that dose, not a potency): 61.2%
The estimate for compound 3 lay 13.2 percentage points below the measured number; the range from low to high includes it.
By their numbers in this assay, from the lowest: compounds 2, 1 and 3 (each within the scatter of the next, the first and the last beyond it).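

Within the data shown here, the change from ((methoxycarbonyl)carbonyl)amino to amino brings a number 11.9 percentage points higher from compound 2 to compound 3 (beyond the scatter) in this assay and gives the first step beyond the scatter at this amine nitrogen, showing that the read-out at this dose does not depend on a substituent there. Hydrogen in place of carboxymethyl brings only a number 7.8 percentage points higher from compound 1 to compound 3 (within the scatter) and leaves those two compounds level, so the exchange of the (methoxycarbonyl)carbonyl group for hydrogen is the only one of the steps at this nitrogen that separates two compounds, and then only modestly. Nothing measured on these compounds accounts for that difference, and the data offer no explanation of it.

On these data alone, it remains open whether a smaller acyl group such as acetyl, a simple methyl group, or a free carboxylic acid in place of the methyl ester on this nitrogen would read with compound 2 or with compound 3. Also open, as far as these compounds go, is whether the step from compound 2 to compound 3 would hold at other doses, since a single dose gives the size of the read-out and not a potency.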